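Working notes: from compound 1 to compound 4

This account rests on a few compounds, and the source may have more. Where it says the series, first, only, none or still open, it means among the compounds named here.

Measured in an ADME assay on HEK-293T cells (Homo sapiens) for cytotoxicity, read by CCK-8 assay, with a stated time of 48 h; a higher number here means a weaker inhibitor, a lower number a stronger inhibitor:
- compound 1 `COc1ccc(Oc2ccc(C(C)C)cc2-c2ccsc2S(=O)(=O)NCCNC(=S)Nc2ccc([N+](=O)[O-])cc2)cc1OC` gives 11400 nM
- compound 2 `O=C(NCCNS(=O)(=O)c1sccc1-c1ccccc1Oc1ccc(O)c(O)c1)Nc1cc(Cl)cc(Cl)c1` gives 10700 nM
- compound 3 `O=C(NCCNS(=O)(=O)c1ccc(-c2ccccc2O[C@H]2CC[C@@H](O)CC2)s1)Nc1ccc([N+](=O)[O-])cc1` gives 8600 nM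

Compound 1 stands level with compound 2 and compound 3, since all three values lie within the scatter of one another. Compound 4 `COc1ccc(Oc2ccc(C(C)C)cc2-c2ccsc2S(=O)(=O)NCCNC(=O)Nc2cc(Cl)cc(Cl)c2)cc1OC` has no reading yet. Its change from compound 1 is a group of 11 heavy atoms (7 carbon, 1 nitrogen, 1 oxygen, 2 chlorine; one six-membered aromatic ring of carbon only) in place of a group of 12 heavy atoms (7 carbon, 2 nitrogen, 2 oxygen, 1 sulfur; one six-membered aromatic ring of carbon only), on an amine nitrogen and the group that enters is (3,5-dichlorophenyl)carbamoyl, on an amine nitrogen. Among the compounds with values here, no measured pair differs in one place, so no measured step in this assay guides the call directly. Compound 2 also carries (3,5-dichlorophenyl)carbamoyl and gives 10700 nM on a different core, a value within the scatter of that of compound 1. The expected step of a 1.1-fold lower number from compound 1 to compound 4 (0.06 log units; within the scatter) is none beyond the scatter, with neither direction favoured. Compound 4 is estimated at 10000 nM with an expected range from 5000 nM to 20000 nM in this assay for now.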

Compound 4, half-maximal inhibitory concentration: 11900 nM
The estimate for compound 4 lay 1.2-fold (0.08 log units) below the measured number; measured number inside the range.
By their numbers in this assay, from the lowest: compounds 3, 2, 1 and 4 (each within the scatter of the next).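

In this assay, within the data shown here, the step of a 1.0-fold higher number from compound 1 to compound 4 (0.02 log units; within the scatter) is the first one that differs in one place, and it lies within the scatter: with (3,5-dichlorophenyl)carbamoyl in place of the group of 12 heavy atoms on an amine nitrogen, the two readings cannot be told apart. Among these compounds, on the core of compound 1, this position therefore carries either group with no difference that this read-out can resolve, which the earlier compounds, with no such pair among them, could not show. No supporting measurement bears on this result.

The step exchanges the sulfur for oxygen and alters the ring substituents together, so the contribution of each stays unresolved. Also open, going by these compounds, is whether a group without an aromatic ring on this nitrogen, such as acetyl or a longer alkyl chain, would read level with these two.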